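Methoxy to trifluoromethyl in a weakly inhibiting pair

The source may report more compounds than this note shows. Statements on the series, on what has been measured and on what is new or still open speak of the compounds shown alone.

In a functional assay on HepG2 cells (Homo sapiens) for inhibition, read by MTT assay, with a stated time of 72 h (a higher number here means a weaker inhibitor, a lower number a stronger inhibitor), compound 1 `O=C(Nc1ccccc1)C1CCN(C/C=C/c2ccccc2)CC1` gives 90900 nM, and compound 2 `COc1cccc(NC(=O)C2CCN(C/C=C/c3ccccc3)CC2)c1` gives 78600 nM. Within the data shown here, compound 2 therefore stands within the scatter of compound 1, the only other compound measured. That one measured step, a 1.2-fold lower number from compound 1 to compound 2 (0.06 log units; within the scatter), is methoxy in place of hydrogen on an aromatic carbon. Compound 3 `O=C(Nc1cccc(C(F)(F)F)c1)C1CCN(C/C=C/c2ccccc2)CC1` carries trifluoromethyl in place of methoxy on an aromatic carbon at the same place: trifluoromethyl in place of methoxy on an aromatic carbon. Among the measured compounds shown here, the measured step bears on this change only indirectly, as it shows methoxy against hydrogen, and no measured compound carries trifluoromethyl. For the measured compounds named here, as the one substituent change measured so far stayed within the scatter, no step beyond the scatter is expected in this assay, and its direction remains open. The expected change is a 1.2-fold lower number from compound 2 to compound 3 (0.08 log units; within the scatter). Compound 3 is estimated at 65000 nM, with an expected range of 28000 nM to 140000 nM.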

Compound 3, half-maximal inhibitory concentration: 11400 nM
The estimate for compound 3 lay 5.7-fold (0.76 log units) above the measured number, and the stated range ends above it.
By their numbers in this assay, from the lowest: compound 3; then compounds 2 and 1 (each within the scatter of the next).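

In this assay the aromatic carbon meta to a large group proves able to carry a change beyond the scatter, which the step from hydrogen to methoxy had not shown. Trifluoromethyl in place of methoxy gives a 6.9-fold lower number from compound 2 to compound 3 (0.84 log units; beyond the scatter) and trifluoromethyl in place of hydrogen gives an 8.0-fold lower number from compound 1 to compound 3 (0.90 log units; beyond the scatter) so the two steps agree in direction. The outcome at this carbon thus depends on which group enters: methoxy leaves the number within the scatter of the hydrogen compound, while trifluoromethyl does not.

As far as these compounds go, whether a chlorine atom, a nitrile or a carboxylic acid on this same carbon would behave like trifluoromethyl or like methoxy stays open, as does the effect of trifluoromethyl elsewhere on the ring. No measurement offered here accounts for the size of these steps.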